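Butoxy to octyl on the cyclohexyl-bearing analogue

The source may report more compounds than this note shows. Statements on the series, on what has been measured and on what is new or still open speak of the compounds shown alone.

Of the compounds shown here, three on a shared core have numbers so far. Compound 1 `CCCCOc1ccc(-c2c(C)[nH]c(=O)n2C)cc1` gives 5100 nM in a functional assay on brain (Rattus norvegicus, strain Wistar) for inhibition; a lower number here means a stronger inhibitor, a higher number a weaker inhibitor. Compound 2 `CCCCOc1ccc(-c2c(C)[nH]c(=O)n2C2CCCCC2)cc1` gives 13900 nM, the highest of the three numbers, separated from compound 1 by a 2.7-fold higher number from compound 1 to compound 2 (0.44 log units; beyond the scatter). Compound 3 `CCCCCCc1ccc(-c2c(C)[nH]c(=O)n2C)cc1` gives 9000 nM, within the scatter of compound 2, and the one-place step a 1.8-fold higher number from compound 1 to compound 3 (0.25 log units; within the scatter) stayed within the scatter. Compound 4 `CCCCCCCCc1ccc(-c2c(C)[nH]c(=O)n2C2CCCCC2)cc1` is not yet measured and differs from compound 2 as follows: octyl in place of butoxy on an aromatic carbon. Among the measured compounds shown here, the only step that bears on this is a 1.8-fold higher number from compound 1 to compound 3 (0.25 log units; within the scatter), a chain replacing butoxy at the same place, which was within the scatter. For the measured compounds named here, the longer octyl has no measured counterpart, so the expected step of a 1.4-fold higher number from compound 2 to compound 4 (0.16 log units; within the scatter) is small, toward a higher number at most. Compound 4 is therefore expected near 20000 nM (range 8000 nM to 50000 nM).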

Compound 4, half-maximal inhibitory concentration: 10300 nM
Compound 4: middle estimate off by 1.9-fold (0.29 log units), on the high side; low and high end bracket the measured number.
By their numbers in this assay, from the lowest: compounds 1, 3, 4 and 2 (each within the scatter of the next, the first and the last beyond it).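

On the cyclohexyl-bearing analogue, octyl in place of butoxy on the aromatic carbon gives a 1.3-fold lower number from compound 2 to compound 4 (0.13 log units; within the scatter) in this assay. The oxygen of butoxy and the hydrogen-bond acceptor it counts can therefore leave this place without a step beyond the scatter, now with cyclohexyl as well as methyl on the aromatic nitrogen. No measured information on the compounds bears on this result.

Open, on these data alone, is whether an amine, a carboxylic acid or a chain longer than octyl at this place would move the number beyond the scatter. Also open, as far as these compounds go, is whether cyclohexyl in place of methyl on the aromatic nitrogen, seen as a 2.7-fold higher number from compound 1 to compound 2 (0.44 log units; beyond the scatter) with butoxy, behaves the same way with octyl.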